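The source may hold more compounds than are shown below. What is called first, only, known or untested is meant among the compounds shown, and "the series" means these compounds.

Compound 1 `CCS[C@@]1(C(=O)O)C=C[C@@H](NC(C)=O)[C@H]([C@H](O)[C@H](O)CO)O1` carries an ethylsulfanyl group on a saturated ring carbon of the shared core. In an assay on HEK293 cells for inhibition of sialidase-3 (Homo sapiens), read by fluorescence, with a stated time of 1 h (on this read-out higher numbers stand for weaker inhibition and lower numbers for stronger inhibition), compound 1 gives no number but only a limit of the assay, > 1000000 nM. Compound 2 `CCCCO[C@@]1(C(=O)O)C=C[C@@H](NC(C)=O)[C@H]([C@H](O)[C@H](O)CO)O1` has butoxy in place of ethylsulfanyl on that saturated ring carbon. In this assay compound 2 likewise reaches only a limit, > 1000000 nM. The step that the two limits leave unreadable from compound 1 to compound 2 therefore cannot be read, since (the limit of > 1000000 nM in this assay, at which 2 of the 2 values shown sit). Compound 3 `CCCCCCCCS[C@@]1(C(=O)O)C=C[C@@H](NC(C)=O)[C@H]([C@H](O)[C@H](O)CO)O1` differs from compound 1 by hexyl in place of hydrogen on a saturated chain carbon, two bonds along the chain from a sulfur. Among the measured compounds shown here, no measured step touches a change of this kind, and the single step measured is itself unreadable, so where compound 1 stands is known only as a limit. On that basis a step that the limit leaves unreadable from compound 1 to compound 3 is expected for compound 3, meaning it is estimated most likely to sit at a limit again, around 1500000 nM with a range from 200000 nM to 10000000 nM.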

Compound 3, half-maximal inhibitory concentration: > 1000000 nM
Compound 3 ended at the assay's limit; the forecaster's own chance of this, stated with the estimate: 75%; the middle value does not contradict the limit.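

Compound 3 also stops at a limit, so its steps from compound 1 and from compound 2 cannot be read: the limit of > 1000000 nM in this assay, at which 3 of the 3 values shown sit.

The compounds shown leave open how they rank in this assay, and whether ethylsulfanyl, butoxy or octylsulfanyl on the saturated ring carbon makes any difference.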